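Adding a Second Chloro to Compound 1

A few compounds are considered here, and "the series" means these few. Any claim that something is new, unique, unknown or untested is made for them only; others in the source may bear on it.

Measured compounds:
compound 1, `COc1ccc(/C=C/C(=O)c2sc(Nc3ccc(Cl)cc3)nc2C)cc1`, in a functional assay on Bel-7402 cells (Homo sapiens) for cytotoxicity, read by MTT assay; on this read-out lower numbers stand for stronger inhibition and higher numbers for weaker inhibition: > 25000 nM
compound 2, `COc1cccc(/C=C/C(=O)c2sc(Nc3ccc(Cl)cc3)nc2C)c1`, in this assay: > 25000 nM

Compound 1 stands at a limit of this assay and not at a number, at > 25000 nM. Compound 2 likewise is reported only as a limit, > 25000 nM. The step from compound 1 to compound 2 is a step that the two limits leave unreadable from compound 1 to compound 2 because both values sit at the limit of > 25000 nM in this assay, at which 2 of the 2 values shown sit. That step is the only measured one, and it gives no size to lean on.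

Compound 3, `COc1ccc(/C=C/C(=O)c2sc(Nc3ccc(Cl)c(Cl)c3)nc2C)cc1`, differs from compound 1 by chloro in place of hydrogen on an aromatic carbon. With no readable step to carry over, the value of compound 3 is expected to sit where compound 1 does, most likely again at a limit. Compound 3 is therefore estimated at 30000 nM, with a range from 8000 nM to 120000 nM. The expected step from compound 1 to compound 3 is a step that the limit leaves unreadable from compound 1 to compound 3.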

Compound 3, half-maximal inhibitory concentration: > 25000 nM
Compound 3 gave a limit, no number; the forecaster's own chance of this, stated with the estimate: 70%; the middle value lies beyond the limit too.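

No step can be read from compound 1 to compound 3, because both are reported only as limits in this assay: the limit of > 25000 nM in this assay, at which 3 of the 3 values shown sit.

As far as these compounds go, how far the true values of compound 1, compound 2 and compound 3 differ, and so what the second chloro changes, stays open.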